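The source may report more compounds than this note shows. Statements on the series, on what has been measured and on what is new or still open speak of the compounds shown alone.

Measured so far in an assay on isolated protein for inhibition of legumain (Mus musculus), read by fluorescence, with stated times of 30 s and 2.5 h; on this read-out lower numbers stand for stronger inhibition and higher numbers for weaker inhibition:
compound 1 `CCOC(=O)/C=C/C(=O)N(CC(N)=O)NC(=O)[C@@H]1CCCN1C(=O)[C@H]1CSCN1C(C)=O` — 167 nM
compound 2 `CCOC(=O)C1OC1C(=O)N(CC(N)=O)NC(=O)[C@@H]1CCCN1C(=O)C1(NC(C)=O)CC1` — 4.4 nM

Compound 1 holds the higher of the two numbers; compound 2 lies at a gap beyond the scatter, but the two differ in more than one place, so nothing can be read from that pair about any single change.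

Compound 3 `C#CC[C@H](NC(C)=O)C(=O)N1CCC[C@H]1C(=O)NN(CC(N)=O)C(=O)/C=C/C(=O)OCC` keeps the core and warhead of compound 1 and differs only by a group of 8 heavy atoms (6 carbon, 1 nitrogen, 1 oxygen; no ring) in place of a group of 8 heavy atoms (5 carbon, 1 nitrogen, 1 oxygen, 1 sulfur; one five-membered non-aromatic ring with 2 hetero atoms), on a carbonyl carbon. Among the compounds with values here, no measured pair shows a change of this kind, so the expected step from compound 1 is small: a 1.1-fold lower number from compound 1 to compound 3 (0.05 log units; within the scatter) is estimated, within the scatter in either direction. Compound 3 is thus expected near 150 nM, plausibly between 45 nM and 500 nM.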

Compound 3, half-maximal inhibitory concentration: 17 nM
Beside the measured number, compound 3's estimate is 8.8-fold (0.95 log units) above it; measured number outside the range, below it.
By their numbers in this assay, from the lowest: compound 2; then compound 3; then compound 1.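

On the carbonyl carbon whose other neighbour is the amide-type nitrogen in a ring, the choice of group matters in this assay: replacing the five-membered non-aromatic ring with 2 hetero atoms by the open-chain group gives a 9.8-fold lower number from compound 1 to compound 3 (0.99 log units; beyond the scatter). This first single-place comparison shows that this position alone can shift the number beyond the scatter, with core and warhead unchanged. Nothing measured here accounts for the step.

Which part of the change carries the step remains open, as the ring, triple bond and hydrogen-bond donor count all change together. Going by these compounds, how a propyl chain or a carboxylic acid would read in this place also remains open.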